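A few compounds are considered here, and "the series" means these few. Any claim that something is new, unique, unknown or untested is made for them only; others in the source may bear on it.

Compound 1, `CCCn1c(=O)[nH]c2nc(-c3ccc(S(=O)(=O)N4CCN(c5ccc(Cl)cc5F)CC4)cc3)[nH]c2c1=O`, in an assay on CHO cells for displacement of a labelled ligand from adenosine receptor A1 (Homo sapiens), read by scintillation counting, with a stated time of 90 min, in the presence of a further agent that is not named here; on this read-out lower numbers stand for stronger inhibition and higher numbers for weaker inhibition: > 1000 nM, which is a limit of the assay, not a number.
Compound 2, `CCCn1c(=O)[nH]c2nc(-c3ccc(S(=O)(=O)N4CCN(Cc5cccc(C)c5)CC4)cc3)[nH]c2c1=O`, in this assay: 795 nM.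
Compound 3, `CCCn1c(=O)[nH]c2nc(-c3ccc(S(=O)(=O)N(C)C)cc3)[nH]c2c1=O`, in this assay: 190 nM.

Compound 2 holds the highest number of the two measured numbers in this assay; compound 3 sits at a lower number, a gap that is beyond the scatter, and the third value, that of compound 1, is only a limit. The unmeasured compound 4, `CCCn1c(=O)[nH]c2nc(-c3ccc(S(=O)(=O)N4CCN(c5ccccc5Br)CC4)cc3)[nH]c2c1=O`, differs from compound 2 by 2-bromophenyl in place of 3-methylbenzyl on an amine nitrogen in a ring. Going by the values given here, one measured step bears on this: an at least 1.2-fold lower number from compound 1 to compound 2 (0.09 log units; that floor lies within the scatter). That step is only a floor because compound 1 sits at the limit of > 1000 nM in this assay, at which 1 of the 3 values shown sits, so it shows that swapping a benzyl for a ring bound directly to the ring nitrogen moved the number by at least a small amount towards a higher value, and perhaps by more. Compound 4 returns to a ring bound directly to that nitrogen, so a higher number than compound 2 is expected in this assay, by a 1.6-fold higher number from compound 2 to compound 4 (0.21 log units; within the scatter), with a real chance that only a limit is reported. The estimate for compound 4 is 1300 nM, within 500 nM to 3500 nM.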

Compound 4, inhibition constant: > 1000 nM
Compound 4: only a limit was reported; the forecaster's own chance of this, stated with the estimate: 50%; the middle value does not contradict the limit.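

In this assay, 2-bromophenyl in place of 3-methylbenzyl gives an at least 1.2-fold higher number from compound 2 to compound 4 (0.09 log units; that floor lies within the scatter), a floor that leaves the true size of the change unknown. Compound 4 is the second compound here with a substituted phenyl ring bound directly to the ring nitrogen to end at a limit rather than a number, after compound 1, whereas compound 2, with its benzyl group, gives a number. The step between compound 1 and compound 4 cannot be read, because both sit at the same limit: the limit of > 1000 nM in this assay, at which 2 of the 4 values shown sit.

On these data alone, how far compound 1 and compound 4 lie past that limit stays open, and so does any ranking of their halogen patterns. Also open, as far as these compounds go, is what an unsubstituted phenyl, a 2-bromobenzyl group or a carboxylic acid on that nitrogen would give in this assay.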